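The source may hold more compounds than are shown below. What is called first, only, known or untested is meant among the compounds shown, and "the series" means these compounds.

Measured so far:
Compound 1 `COc1cc(-c2cc(/C=C/C(=O)c3ccc(Cl)c(Cl)c3)[nH]n2)cc(OC)c1OC`; in a functional assay on MDA-MB-468 cells (Homo sapiens) for inhibition, read by sulforhodamine B assay, with a stated time of 48 h (on this read-out lower numbers stand for higher toxicity in this test and higher numbers for lower toxicity in this test), compound 1 reports only a limit, > 100000 nM.
Compound 2 `COc1ccc(C(=O)/C=C/c2cc(-c3cc(OC)c(OC)c(OC)c3)n[nH]2)cc1OC`; in this assay compound 2 gives 5210 nM.

Among the measured compounds shown here, compound 2 holds the only number so far in this assay; the one other value is a limit, (the limit of > 100000 nM in this assay, at which 1 of the 2 values shown sits), and says nothing more than that. Compound 3 `COc1ccc(C(=O)/C=C/c2cc(-c3cc(OC)c(OC)c(OC)c3)n[nH]2)cc1` differs from compound 2 by hydrogen in place of methoxy on an aromatic carbon. For the measured compounds named here, the single measured step, an at least 19-fold lower number from compound 1 to compound 2 (1.28 log units; beyond the scatter), concerns the same ring on the carbonyl carbon but a different exchange, so it bears on the present change only loosely: it shows that this ring can move the read-out a long way, but no measured step removes a methoxy. Going by the values given here, with no direct precedent, a small weakening is expected, a 1.7-fold higher number from compound 2 to compound 3 (0.24 log units; within the scatter), well inside the swing already seen on this ring. Compound 3 is therefore estimated at 9000 nM, with a range from 2500 nM to 35000 nM.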

Compound 3, concentration lethal to 50% of the cells: 5450 nM
Estimate against measurement, compound 3: 1.7-fold (0.22 log units) above, and the stated range covers the measured number.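

In this assay the exchange of 3,4-dimethoxyphenyl for 4-methoxyphenyl gives a 1.0-fold higher number from compound 2 to compound 3 (0.02 log units; within the scatter) and so leaves compound 2 and compound 3 indistinguishable in this test. The 4-methoxyphenyl ring on the carbonyl carbon is thus enough to keep the large separation from the 3,4-dichlorophenyl ring, with an at least 18-fold lower number from compound 1 to compound 3 (1.26 log units; beyond the scatter) as the step, and this separation does not require a second methoxy. The value of compound 1 is a limit, not a number, so the true size of both steps from it stays unknown: the limit of > 100000 nM in this assay, at which 1 of the 3 values shown sits.

Still open is whether the remaining methoxy is needed at all, since neither an unsubstituted phenyl ring nor a hydroxy or an amine in its place appears among these compounds. The compounds shown also leave open what the trimethoxyphenyl ring contributes, as all of them carry it unchanged.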